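Trimming the Piperazine Chain End: Ethyl to Methyl

A few compounds are considered here, and "the series" means these few. Any claim that something is new, unique, unknown or untested is made for them only; others in the source may bear on it.

Three compounds share one core. Compound 1 `COc1cc2c(Oc3c(F)cc(NC(=O)NN4C(=O)C(C)(C)SC4c4c(F)cccc4F)cc3F)ccnc2cc1OCCCN1CCCC1` stands as "not determined" (no result reported) in a functional assay on MDA-MB-231 cells (Homo sapiens) for antiproliferative activity, read by MTT assay, with a stated time of 72 h (a lower number here means a stronger inhibitor, a higher number a weaker inhibitor), so no number is available for it. For the measured compounds named here, compound 2 `COc1cc2c(Oc3c(F)cc(NC(=S)NN4C(=O)CSC4c4c(F)cccc4F)cc3F)ccnc2cc1OCCCN1CCCC1` gives 8120 nM in this assay, while compound 3 `CCN1CCN(CCCOc2cc3nccc(Oc4c(F)cc(NC(=O)NN5C(=O)CSC5c5c(F)cccc5F)cc4F)c3cc2OC)CC1` gives 3100 nM, the lower of the two known numbers and beyond the scatter from compound 2. Compound 4 `COc1cc2c(Oc3c(F)cc(NC(=O)NN4C(=O)CSC4c4c(F)cccc4F)cc3F)ccnc2cc1OCCCN1CCN(C)CC1` differs from compound 3 only by hydrogen in place of methyl on a saturated chain carbon bound to an amine nitrogen in a ring. Going by the values given here, no step between two measured compounds shows what such a change does; a change of a single carbon on this chain end is expected to move the number little, in no clear direction, and not beyond the scatter. Compound 4 is therefore expected to give about 3000 nM in this assay, within 1200 nM to 8000 nM. The expected step, a 1.0-fold lower number from compound 3 to compound 4 (0.01 log units; within the scatter), stays inside the scatter.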

Compound 4, half-maximal inhibitory concentration: 4360 nM
Estimate against measurement, compound 4: 1.5-fold (0.16 log units) below, within the range that was stated.
By their numbers in this assay, from the lowest: compounds 3, 4 and 2 (each within the scatter of the next, the first and the last beyond it).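

Going from 4-ethylpiperazin-1-yl to 4-methylpiperazin-1-yl gives, in this assay, a 1.4-fold higher number from compound 3 to compound 4 (0.15 log units; within the scatter), the first direct reading of this position. On this one pair, the two chain ends cannot be told apart. No measurement shown bears on the reason for this result. Going by these compounds, it stays open whether a propyl chain, a hydroxyethyl chain or a benzyl group at this chain end would also stay within the scatter of compound 3. The same holds for a piperazine carrying only hydrogen on that nitrogen.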